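The source may hold more compounds than are shown below. What is called first, only, known or untested is meant among the compounds shown, and "the series" means these compounds.

Three compounds sharing one core have been measured in a functional assay on CHO cells (Cricetulus griseus) for inhibition; on this read-out higher numbers stand for weaker inhibition and lower numbers for stronger inhibition:

- compound 1 `CC/C=C\CCOc1cc(CCc2nc(C)c(CC)s2)nc(NCc2cc(Cl)cc(NC(=O)OC(C)C)c2)c1` gives 64 nM
- compound 2 `CCc1sc(CCc2cc(OC(CC)CC)cc(NCc3cc(Cl)cc(NC(=O)OC(C)C)c3)n2)nc1C` gives 33 nM
- compound 3 `CCc1sc(CCc2cc(OC3CCOCC3)cc(NCc3cc(Cl)cc(NC(=O)OC(C)C)c3)n2)nc1C` gives 42 nM

Compound 3 at 42 nM lies within the scatter of both other compounds, so no order can be drawn among the three. Compound 4 `CCc1sc(CCc2cc(OCCCc3cccnc3)cc(NCc3cc(Cl)cc(NC(=O)OC(C)C)c3)n2)nc1C` has not yet been measured. It differs from compound 3 in one place: 3-(pyridin-3-yl)propyl in place of oxan-4-yl on an oxygen on an aromatic ring. In words, 3-(pyridin-3-yl)propyl stands in place of oxan-4-yl on an oxygen on an aromatic ring.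

The measured steps at this same oxygen are a 1.5-fold lower number from compound 1 to compound 3 (0.18 log units; within the scatter), a 1.3-fold higher number from compound 2 to compound 3 (0.10 log units; within the scatter) and a 1.9-fold lower number from compound 1 to compound 2 (0.29 log units; within the scatter), and all of them stay within the scatter. None of the groups measured there carries an aromatic ring, so these steps reach compound 4 only loosely. No step beyond the scatter is therefore expected in this assay, in either direction, though the range is kept wide. The expected step is a 1.1-fold higher number from compound 3 to compound 4 (0.03 log units; within the scatter). For compound 4 the estimated value is 45 nM, with an expected range from 20 nM to 100 nM.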

Compound 4, half-maximal inhibitory concentration: 46 nM
Estimate against measurement, compound 4: 1.0-fold (0.01 log units) below; low and high end bracket the measured number.
By their numbers in this assay, from the lowest: compounds 2, 3, 4 and 1 (each within the scatter of the next).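

In this assay, for the compounds shown here, this oxygen on an aromatic ring now carries a group with a six-membered aromatic ring for the first time, and 3-(pyridin-3-yl)propyl in place of oxan-4-yl gives a 1.1-fold higher number from compound 3 to compound 4 (0.04 log units; within the scatter) as its step. The comparisons with the two open-chain groups read the same way, with a 1.4-fold higher number from compound 2 to compound 4 (0.14 log units; within the scatter) in one case and a 1.4-fold lower number from compound 1 to compound 4 (0.14 log units; within the scatter) in the other. Four groups that differ in size, ring content and hetero atoms thus stay within the scatter of one another at this position, so the assay does not separate them.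

Going by these compounds, whether the ring nitrogen matters would take 3-phenylpropyl to show, and whether any group here moves the number beyond the scatter remains open for groups such as a primary amine or a carboxylic acid at the end of the chain. No measurement available here bears on why the steps at this oxygen stay so small.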